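A few compounds are considered here, and "the series" means these few. Any claim that something is new, unique, unknown or untested is made for them only; others in the source may bear on it.

Going by the values given here, in a functional assay on MDA-MB-231 cells (Homo sapiens) for antiproliferative activity, read by MTT assay, with a stated time of 48 h (a higher number here means a weaker inhibitor, a lower number a stronger inhibitor), compound 1 `C#CCOC(=O)/C(C)=C/CC/C(C)=C/CC/C(C)=C/CC[C@@H]1[C@@]2(C)CCC(=O)C(C)(C)[C@H]2CC[C@@]1(C)O` gives 114000 nM, the only actual number so far. Compound 2 `COc1ccc(-n2cc(COC(=O)/C(C)=C/CC/C(C)=C/CC/C(C)=C/CC[C@@H]3[C@@]4(C)CCC(=O)C(C)(C)[C@H]4CC[C@@]3(C)O)nn2)cc1` reads > 150000 nM, which is a limit of the assay. Compound 3 `C/C(=C\CC/C(C)=C/CC[C@@H]1[C@@]2(C)CCC(=O)C(C)(C)[C@H]2CC[C@@]1(C)O)CC/C=C(\C)C(=O)OCc1cn(-c2ccccc2)nn1` reads > 150000 nM, also a limit. The evidence therefore stops at the limit of > 150000 nM in this assay, at which 2 of the 3 values shown sit.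

Compound 4 `C/C(=C\CC/C(C)=C/CC[C@@H]1[C@@]2(C)CCC(=O)C(C)(C)[C@H]2CC[C@@]1(C)O)CC/C=C(\C)C(=O)OCc1cn(-c2cccc(F)c2)nn1` is still unmeasured, and its change is 1-(3-fluorophenyl)-1H-1,2,3-triazol-4-yl in place of ethynyl on a saturated chain carbon bound to an oxygen next to a carbonyl group. The closest measured change is the one that brings in 1-phenyl-1H-1,2,3-triazol-4-yl in place of ethynyl, giving an at least 1.3-fold higher number from compound 1 to compound 3 (0.11 log units; that floor lies within the scatter). The other measured step, hydrogen in place of methoxy on an aromatic carbon, gives a step that the two limits leave unreadable from compound 2 to compound 3, so it offers no size to carry over.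

A step towards a higher number is therefore expected in this assay, in line with compound 3 at > 150000 nM, though its size cannot be fixed and it may not clear the scatter. Compound 4 is estimated at 170000 nM, with an expected range from 100000 nM to 300000 nM. This estimate means an expected 1.5-fold higher number from compound 1 to compound 4 (0.17 log units; within the scatter).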

Compound 4, half-maximal inhibitory concentration: 144000 nM
Beside the measured number, compound 4's estimate is 1.2-fold (0.07 log units) above it; the range from low to high includes it.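

In this assay, going by these compounds alone, compound 4 gives the first actual number for a triazole-bearing group on the saturated chain carbon bound to an oxygen next to a carbonyl group. Exchanging ethynyl for this two-ring group gives a 1.3-fold higher number from compound 1 to compound 4 (0.10 log units; within the scatter), so the much larger group leaves the number within the scatter of the small one. Fluoro in place of hydrogen on an aromatic carbon gives an at least 1.0-fold lower number from compound 3 to compound 4 (0.01 log units; that floor lies within the scatter), and 3-fluorophenyl in place of 4-methoxyphenyl on an aromatic nitrogen gives an at least 1.0-fold lower number from compound 2 to compound 4 (0.01 log units; that floor lies within the scatter), but neither size is fixed because these comparisons end at a limit: the limit of > 150000 nM in this assay, at which 2 of the 4 values shown sit.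

No group shown at this place moves the number beyond the scatter, so it remains open whether any can. Going by these compounds, what an amine or a carboxylic acid on the aromatic ring would give also stays open.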